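The compounds below may be only part of what the source reports. "The series", "measured", "known", "first", "only" and "open" are said of these compounds alone.

Working notes on the series. Compound 1 `C[C@@H](O)[C@H]1C(=O)N2C(C(=O)OCOC(=O)O[C@H]3CCCc4ccccc43)=C(S[C@@H]3CN[C@H](C(=O)N(C)C)C3)[C@H](C)[C@H]12` is the reference here. In a physicochemical assay for metabolic stability, read by HPLC, at pH 7.4, tested at 100 uM (a lower number here means that the compound disappears faster, a higher number that the compound lasts longer), compound 1 gives 0.0233 h. For the measured compounds named here, its only measured neighbour is compound 2 `C[C@@H](O)[C@H]1C(=O)N2C(C(=O)OCOC(=O)O[C@@H]3CCCc4ccccc43)=C(S[C@@H]3CN[C@H](C(=O)N(C)C)C3)[C@H](C)[C@H]12`, which in this assay gives 0.025 h. The step of a 1.1-fold higher number from compound 1 to compound 2 (0.03 log units; within the scatter) is within the scatter, and the two compounds sit at the same level on this read-out; the only thing that separates them is the fact that compounds 1 and 2 differ only in the configuration as drawn. Compound 1 therefore stands at a short half-life with nothing measured beside it that moves the number.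

Compound 3 `C[C@@H](O)[C@H]1C(=O)N2C(C(=O)OCOC(=O)O[C@H]3CCCCc4ccccc43)=C(S[C@@H]3CN[C@H](C(=O)N(C)C)C3)[C@H](C)[C@H]12` has not been measured. It differs from compound 1 by a group of 11 heavy atoms (11 carbon; one six-membered aromatic ring of carbon only, one seven-membered non-aromatic ring of carbon only) in place of a group of 10 heavy atoms (10 carbon; one six-membered non-aromatic ring of carbon only, one six-membered aromatic ring of carbon only), on an oxygen next to a carbonyl group. Going by the values given here, no measured step covers a change of this kind: the step from compound 1 to compound 2 touches only the configuration at one carbon and was within the scatter, so it gives no direction for a ring enlargement on the same carbonate oxygen. The expectation in this assay for compound 3 is therefore a step of a 1.1-fold higher number from compound 1 to compound 3 (0.03 log units; within the scatter), not beyond the scatter. Compound 3 is estimated at 0.025 h, with a range from 0.012 h to 0.055 h.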

Compound 3, half-life: 0.467 h
The estimate for compound 3 lay 19-fold (1.27 log units) below the measured number, and the stated range ends below it.
By their numbers in this assay, from the lowest: compounds 1 and 2 (each within the scatter of the next); then compound 3.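

On the oxygen next to a carbonyl group, the ring carried there proves to matter in this assay: with the seven-membered non-aromatic ring in place of the 1,2,3,4-tetrahydronaphthalen-1-yl ring, the half-life moves well beyond the scatter (a 20-fold higher number from compound 1 to compound 3 (1.30 log units; beyond the scatter)) and (a 19-fold higher number from compound 2 to compound 3 (1.27 log units; beyond the scatter)). For the compounds shown here, the earlier pair showed only that a change of configuration at one ring carbon left the number in place, whereas this change of ring size separates compound 3 from both compound 1 and compound 2. Nothing available accounts for the size of this step.

As far as these compounds go, whether the opposite configuration of the seven-membered ring keeps this half-life remains open. Also open, from the compounds shown here alone, is whether the trend continues with an eight-membered ring, or whether an open-chain group such as benzyl on the same oxygen gives a similar number.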